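Halogen exchange on the aryl thiourea of the shared core

This account rests on a few compounds, and the source may have more. Where it says the series, first, only, none or still open, it means among the compounds named here.

Measured so far in an ADME assay on MT4 cells (Homo sapiens) for cytotoxicity, read by MTT assay, with a stated time of 96 h; a higher number here means that more compound is tolerated, a lower number that less compound is tolerated:
Compound 1 `Cc1ccc(NC(=S)Nc2nc[nH]n2)cc1` gives 59000 nM.
Compound 2 `S=C(Nc1ccccc1)Nc1nc[nH]n1` gives only a limit of the assay, > 100000 nM.
Compound 3 `S=C(Nc1ccc(I)cc1)Nc1nc[nH]n1` gives 46000 nM.

Compound 3 holds the lowest of the two numbers in this assay; its nearest neighbour is compound 1, whose number is within the scatter of it. Compound 4 `S=C(Nc1ccc(Cl)cc1)Nc1nc[nH]n1` differs from compound 3 by chloro in place of iodo on an aromatic carbon. The step of an at least 2.1-fold lower number from compound 2 to compound 3 (0.33 log units; beyond the scatter) shows that a halogen entering this position moved the number modestly downward, while the step of a 1.3-fold lower number from compound 1 to compound 3 (0.11 log units; within the scatter) stayed within the scatter. Exchanging one halogen for another is therefore expected to give a step of about a 1.1-fold higher number from compound 3 to compound 4 (0.04 log units; within the scatter), none beyond the scatter. Compound 4 is estimated at 50000 nM, between 25000 nM and 100000 nM.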

Compound 4, half-maximal cytotoxic concentration: 47000 nM
The estimate for compound 4 lay 1.1-fold (0.03 log units) above the measured number; low and high end bracket the measured number.
By their numbers in this assay, from the lowest: compounds 3, 4 and 1 (each within the scatter of the next). At a limit, above all of these: compound 2.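

In this assay chloro and iodo are not told apart on this aromatic carbon, with a 1.0-fold higher number from compound 3 to compound 4 (0.01 log units; within the scatter) as the step between them. Chloro now repeats what iodo showed against hydrogen, with an at least 2.1-fold lower number from compound 2 to compound 4 (0.32 log units; beyond the scatter) as a floor, and against methyl, where a 1.3-fold lower number from compound 1 to compound 4 (0.10 log units; within the scatter) leaves the two groups unresolved. The hydrogen end of that floor, compound 2, is only a limit of the assay: the limit of > 100000 nM in this assay, at which 1 of the 4 values shown sits.

Open, on these data alone, is whether fluoro, or a group of another kind such as an amine or a carboxylic acid, would sit with compounds 1, 3 and 4 or with compound 2 at this position.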